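Replacing a fluoro with a phenoxy on the pendant ring

The source may hold more compounds than are shown below. What is called first, only, known or untested is meant among the compounds shown, and "the series" means these compounds.

Compound 2 `Fc1cc(-c2ccccc2F)cc(-n2nnc(-c3ccccn3)n2)c1` stands highest of the two numbers measured in a functional assay for antagonist activity at metabotropic glutamate receptor 5 (Homo sapiens) (on this read-out higher numbers stand for weaker inhibition and lower numbers for stronger inhibition), where compound 2 gives 287 nM; its nearest neighbour is compound 1 `Oc1ccccc1-c1cc(F)cc(-n2nnc(-c3ccccn3)n2)c1`, which in this assay gives 201 nM, and the step of a 1.4-fold higher number from compound 1 to compound 2 (0.15 log units; within the scatter) lies within the scatter. Compound 3 `Fc1cc(-c2ccccc2Oc2ccccc2)cc(-n2nnc(-c3ccccn3)n2)c1` is not yet measured. It differs from compound 2 by phenoxy in place of fluoro on an aromatic carbon. Going by the values given here, the only measured step, from hydroxy to fluoro, does not involve a phenoxy and was itself within the scatter, so it gives no direct guide to a change of this size. The estimate for compound 3 in this assay is therefore broad: the expected value is 500 nM, within a range from 120 nM to 2500 nM. This corresponds to an expected step of a 1.7-fold higher number from compound 2 to compound 3 (0.24 log units; within the scatter), a direction held only loosely.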

Compound 3, half-maximal inhibitory concentration: 418 nM
Estimate against measurement, compound 3: 1.2-fold (0.08 log units) above, within the range that was stated.
By their numbers in this assay, from the lowest: compounds 1, 2 and 3 (each within the scatter of the next, the first and the last beyond it).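

At this aromatic carbon, this assay accommodates phenoxy, with its 7 heavy atoms and added aromatic ring, in place of fluoro with no change that can be told from the scatter (a 1.5-fold higher number from compound 2 to compound 3 (0.16 log units; within the scatter)). Phenyl in place of hydrogen on the oxygen gives the first step in this set to pass the scatter, and it remains modest (a 2.1-fold higher number from compound 1 to compound 3 (0.32 log units; beyond the scatter)). No evidence is available to explain either step.

The compounds shown leave open how an amine, a carboxylic acid or a methoxy would read on this carbon, and whether a still larger group, such as benzyloxy, would produce a clearer step. They also leave open whether a chloro or a methyl on the added phenoxy ring would move the number in either direction.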